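Allyloxy in place of ethyl on the shared core

The compounds below may be only part of what the source reports. "The series", "measured", "known", "first", "only" and "open" are said of these compounds alone.

In a functional assay on MCF7 cells (Homo sapiens) for inhibition, read by radiometric assay and XTT assay (on this read-out lower numbers stand for stronger inhibition and higher numbers for weaker inhibition), compound 1 (`CCCCCCCC[C@@]1(C)SC(=O)C=C1OCC(=O)O`) gives 50.3 ug/mL and compound 2 (`CCCCCCCC[C@@]1(C)SC(=O)C=C1OC(=O)CC`) gives 26.8 ug/mL. Within the data shown here, compound 2 thus stands within the scatter of compound 1, its only neighbour on the numbers: a 1.9-fold lower number from compound 1 to compound 2 (0.27 log units; within the scatter). Compound 3 (`C=CCOC(=O)OC1=CC(=O)S[C@]1(C)CCCCCCCC`) carries allyloxy in place of ethyl on a carbonyl carbon. That one measured step bears only indirectly, as it involves a different group, and it gives no reason to expect a shift beyond the scatter in this assay. The estimated step is a 1.1-fold higher number from compound 2 to compound 3 (0.05 log units; within the scatter). For compound 3 the expected value is 30 ug/mL, with an estimated range of 14 ug/mL to 62 ug/mL.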

Compound 3, half-maximal inhibitory concentration: 37.3 ug/mL
Compound 3: the middle estimate sits 1.2-fold (0.09 log units) below what was measured; measured number inside the range.
By their numbers in this assay, from the lowest: compounds 2, 3 and 1 (each within the scatter of the next).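

In this assay, allyloxy in place of ethyl on a carbonyl carbon (a 1.4-fold higher number from compound 2 to compound 3 (0.14 log units; within the scatter)) and allyloxycarbonyl in place of carboxymethyl on an oxygen on an unsaturated carbon (a 1.3-fold lower number from compound 1 to compound 3 (0.13 log units; within the scatter)) both stay within the scatter. The site therefore now takes a third group, this one adding a double bond outside aromatic rings and a hydrogen-bond acceptor, and all three compounds remain within the scatter of one another. No evidence accompanies these numbers to explain them. As far as these compounds go, whether an amine or a benzyl group on that carbonyl carbon would move the number beyond the scatter remains open.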